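A few compounds are considered here, and "the series" means these few. Any claim that something is new, unique, unknown or untested is made for them only; others in the source may bear on it.

Working notes on the series. In a functional assay on HEK293 cells for agonist activity at Free fatty acid receptor 1 (Homo sapiens), read by HTRF and inositol phosphate accumulation, with a stated time of 60 min (a higher number here means that more compound is needed for the effect, a lower number that less compound is needed), compound 1 `O=C(O)CC[C@H]1CCc2cc(-c3cc(OC(F)(F)F)cc(Cl)c3F)ccc2O1` gives 2200 nM. Compound 2 `COc1cc(OC2CCC2)cc(-c2ccc3c(c2)CC[C@H](CCC(=O)O)O3)c1F` gives only a limit in this assay, namely > 10000 nM. Compound 3 `COc1cc(OC(F)(F)F)cc(-c2ccc3c(c2)CC[C@H](CCC(=O)O)O3)c1F` is still to be measured in this assay. Compound 3 differs from compound 2 by trifluoromethyl in place of cyclobutyl on an oxygen on an aromatic ring; cut one bond further out, the change reads cyclobutyloxy to trifluoromethoxy. Among the measured compounds shown here, no step between measured compounds is available, and compound 2 sits at the limit of > 10000 nM in this assay, at which 1 of the 2 values shown sits, so the size of this step cannot be read from the data. Compound 1 also carries trifluoromethoxy and gives 2200 nM. The step is expected to be an at least 3.3-fold lower number from compound 2 to compound 3 (0.52 log units; beyond the scatter), toward less compound needed. Compound 3 is expected at 3000 nM, between 800 nM and 10000 nM.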

Compound 3, half-maximal effective concentration: 4400 nM
Compound 3: middle estimate off by 1.5-fold (0.17 log units), on the low side; the range from low to high includes it.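

In this assay, trifluoromethoxy in place of cyclobutyloxy gives an at least 2.2-fold lower number from compound 2 to compound 3 (0.35 log units; beyond the scatter) and puts a lower bound on this change at this place on the aromatic ring. On these data alone, the value of compound 2 is a limit, not a number, so the full size of the step stays unknown: the limit of > 10000 nM in this assay, at which 1 of the 3 values shown sits. With trifluoromethoxy present, methoxy in place of chloro gives a 2.0-fold higher number from compound 1 to compound 3 (0.30 log units; within the scatter) and does not separate the two groups. Open, as far as these compounds go, is how a hydroxyl or a longer alkoxy chain on that aromatic ring would read, and whether an amine in place of chloro or methoxy would separate from both.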